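This account rests on a few compounds, and the source may have more. Where it says the series, first, only, none or still open, it means among the compounds named here.

Measured compounds:
- compound 1 `Cc1ccc(OCCCON2C(N)=NC(N)=NC23CCOCC3)cc1`: "not determined" (no result reported)
- compound 2 `NC1=NC2(CCOCC2)N(OCCCOc2ccccc2Cl)C(N)=N1`: 88.2%

For the measured compounds named here, compound 1 carries no numerical result in an assay on isolated protein for inhibition of Dihydrofolate reductase (Homo sapiens), read by spectrophotometry, using NADPH, with stated times of 5 s and 6 min, tested at 50 uM; on this read-out lower numbers stand for a weaker effect and higher numbers for a stronger effect at the one concentration tested; compound 2 is therefore the only compound of the series with a number in this assay, and with compound 2 giving 88.2% the effect at the single concentration is strong. Going by the values given here, no step between two measured compounds is available, so nothing can be said yet about how this series responds to small changes.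

Compound 3 `NC1=NC2(CCOCC2)N(OCCCOc2ccccc2Br)C(N)=N1` is the next compound to be measured. It differs from compound 2 by bromo in place of chloro on an aromatic carbon. Among the compounds with values here, since no measured step exists to compare against, the expectation rests only on compound 2 and the small size of the change.

The step of a number 0.2 percentage points lower from compound 2 to compound 3 (within the scatter) is expected to stay within the usual scatter of this assay, with no clear direction. Compound 3 is accordingly estimated at 88% in this assay, within a range from 75% to 96%.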

Compound 3, a percentage reported as inhibition, at one concentration (the size of the read-out at that concentration, not a potency): 85%
Beside the measured number, compound 3's estimate is 3 percentage points above it; the range from low to high includes it.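

For the compounds shown here, the first measured step, a number 3.2 percentage points lower from compound 2 to compound 3 (within the scatter), shows that in this assay chloro and bromo cannot be told apart on this aromatic carbon, ortho to a large group. Both compounds give a strong effect at the single concentration tested, so this position accepts either group without a readable difference in this read-out. No measured property bears on this result, and the data offer no explanation for it.

Open, from the compounds shown here alone, is whether the position would respond to a group other than these two, such as methoxy, an amine or a carboxylic acid, or to a longer chain in place of the present linker. A percentage at one concentration is also not a potency, so any difference in potency between compound 2 and compound 3 remains unresolved.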